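The source may hold more compounds than are shown below. What is called first, only, known or untested is meant among the compounds shown, and "the series" means these compounds.

Measured so far, in a functional assay on Malme-3M cells (Homo sapiens) for inhibition; a lower number here means a stronger inhibitor of growth, a higher number a weaker inhibitor of growth:
- compound 1, `COc1cc(/C=C/C(=O)c2cccc(-n3cc(-c4ccccc4)[nH]c3=O)c2)ccc1O`, gives 2670 nM
- compound 2, `O=C(/C=C/c1cccc(O)c1)c1cccc(-n2cc(-c3ccc(Cl)cc3)[nH]c2=O)c1`, gives 1830 nM
- compound 3, `COc1ccc(-c2cn(-c3cccc(C(=O)/C=C/c4ccc(O)c(OC)c4)c3)c(=O)[nH]2)cc1`, gives 4420 nM

Compound 3 has the highest of the three numbers in this assay. Its nearest neighbour is compound 1, whose number is lower, but only within the scatter; compound 2 lies further off, with a number lower by more than the scatter. The one single-point step among these three runs a 1.7-fold higher number from compound 1 to compound 3 (0.22 log units; within the scatter), so adding a methoxy to the phenyl ring changed nothing that can be trusted.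

Compound 4, `COc1cc(/C=C/C(=O)c2cccc(-n3cc(-c4ccc(Cl)cc4)[nH]c3=O)c2)ccc1O`, has not been measured. It differs from compound 3 by chloro in place of methoxy on an aromatic carbon. Within the data shown here, no measured pair isolates this exact swap. Compound 2 carries the same chloro group, but it also differs from compound 3 in the other aromatic ring, so only the two numbers can be set side by side: compound 2 gives 1830 nM, while compound 3 gives 4420 nM. Taken with compound 1, where hydrogen at this position gives 2670 nM, the swap is expected to move the number downward by a modest amount, a 2.1-fold lower number from compound 3 to compound 4 (0.32 log units; beyond the scatter), though a result within the scatter of compound 3 would not surprise. Compound 4 is therefore estimated at 2100 nM, with a likely range from 900 nM to 4800 nM.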

Compound 4, concentration for 50% growth inhibition: 3060 nM
For compound 4 the middle estimate is 1.5-fold (0.16 log units) below the measured one, and the stated range covers the measured number.
By their numbers in this assay, from the lowest: compounds 2, 1, 4 and 3 (each within the scatter of the next, the first and the last beyond it).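

In this assay, the methoxy-to-chloro swap on the ring, para to a large group, gives only a small step (a 1.4-fold lower number from compound 3 to compound 4 (0.16 log units; within the scatter)), and chloro in place of hydrogen at the same position gives another (a 1.1-fold higher number from compound 1 to compound 4 (0.06 log units; within the scatter)), both within the scatter. Together with the step from hydrogen to methoxy, this means that hydrogen, methoxy and chloro at this position cannot be told apart here, so the assay shows no preference among these three groups. With chloro held in place, 4-hydroxy-3-methoxyphenyl in place of 3-hydroxyphenyl at the other end of the molecule also gives a step within the scatter (a 1.7-fold higher number from compound 2 to compound 4 (0.22 log units; within the scatter)), and no information beyond these growth numbers is available to account for any of these results.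

These compounds leave open whether an amine, a carboxylic acid or a longer chain at this position would shift the number beyond the scatter. They also leave open how a single hydroxy or a trifluoromethyl on the ring at the other end would behave on the shared core.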